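Methyl for Hydroxy Hydrogen on the Shared Core

This account rests on a few compounds, and the source may have more. Where it says the series, first, only, none or still open, it means among the compounds named here.

Compound 1, `O=C(Nc1cccc(-n2cc(-c3ccncc3)c(-c3cc(O)cc(Cl)c3)n2)c1)Nc1ccc(Cl)c(C(F)(F)F)c1`: 83%
Compound 2, `O=C(Nc1cccc(-n2cc(-c3ccncc3)c(-c3cc(O)cc(Cl)c3)n2)c1)Nc1ccc(Cl)c(Cl)c1`: 93%

In a functional assay on UO-31 cells (Homo sapiens) for inhibition, read by sulforhodamine B assay, with a stated time of 48 h, tested at 0.1 uM (on this read-out higher numbers stand for a weaker effect at the one concentration tested and lower numbers for a stronger effect), compound 1 gives 83%, the lowest of the two numbers; the nearest is compound 2, which gives 93%, and a number 10 percentage points higher from compound 1 to compound 2 (within the scatter). Compound 3, `COc1cc(Cl)cc(-c2nn(-c3cccc(NC(=O)Nc4ccc(Cl)c(C(F)(F)F)c4)c3)cc2-c2ccncc2)c1`, differs from compound 1 by methyl in place of hydrogen on an oxygen on an aromatic ring. Going by the values given here, no measured step touches this oxygen, and the only step available, at a different place, lies within the scatter. Compound 3 is therefore expected to show a number 6 percentage points higher from compound 1 to compound 3 (within the scatter), with nothing beyond the scatter anticipated. The estimate for compound 3 is 89%, ranging from 75% to 103%.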

Compound 3, a percentage reported as activity, at one concentration (the size of the read-out at that concentration, not a potency): 55%
The estimate for compound 3 lay 34 percentage points above the measured number; the whole stated range lies above it.
By their numbers in this assay, from the lowest: compound 3; then compounds 1 and 2 (each within the scatter of the next).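

Going by these compounds alone, changing hydroxy to methoxy on the 3-chloro-5-hydroxyphenyl group gives the first step here that lies beyond the scatter in this assay (a number 28 percentage points lower from compound 1 to compound 3 (beyond the scatter)). This oxygen is therefore a place where a single added methyl alters the read-out, unlike the change at the other place (a number 10 percentage points higher from compound 1 to compound 2 (within the scatter)). Nothing available accounts for the shift. On these data alone, it remains open whether an ethoxy group, or an amine in place of the oxygen, would shift the number further. As far as these compounds go, it is also open whether the methoxy step holds when chloro replaces trifluoromethyl.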